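The source may report more compounds than this note shows. Statements on the series, on what has been measured and on what is new or still open speak of the compounds shown alone.

Among the measured compounds shown here, compound 2 `CC/C(=C(/c1ccc(/C=C/C(=O)O)cc1)c1cc2ccccc2[nH]1)c1ccccc1C#N` gives the lowest of the two numbers measured so far: in a functional assay on MCF7 cells (Homo sapiens) for inhibition (on this read-out higher numbers stand for weaker inhibition and lower numbers for stronger inhibition), compound 2 gives 9 nM, whereas compound 1 `CC/C(=C(/c1ccc(/C=C/C(=O)O)cc1)c1cc2ccccc2[nH]1)c1ccccc1` gives 108 nM in this assay. For the measured compounds named here, the single step recorded between those two, a 12-fold lower number from compound 1 to compound 2 (1.08 log units; beyond the scatter), came from a cyano in place of hydrogen on an aromatic carbon. Compound 3 `CC/C(=C(/c1ccc(/C=C/C(=O)O)cc1)c1cc2ccccc2[nH]1)c1ccccc1C(F)(F)F` has not yet been measured in this assay. It differs from compound 2 by trifluoromethyl in place of cyano on an aromatic carbon. Going by the values given here, no measured step exchanges one substituent for another on that aromatic carbon; the only step that bears on the site is the large one already described, which shows that what sits on that carbon can move the number strongly. Whether trifluoromethyl carries the same gain as cyano cannot be read from two compounds, so the expectation is a modest loss relative to compound 2, with wide uncertainty. Compound 3 is therefore estimated to give 30 nM in this assay, between 8 nM and 120 nM. That expected step reads a 3.3-fold higher number from compound 2 to compound 3 (0.52 log units; beyond the scatter).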

Compound 3, half-maximal inhibitory concentration: 8 nM
Compound 3: the middle estimate sits 3.8-fold (0.57 log units) above what was measured; measured number inside the range.
By their numbers in this assay, from the lowest: compounds 3 and 2 (each within the scatter of the next); then compound 1.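

In this assay, trifluoromethyl in place of cyano on this aromatic carbon gives a 1.1-fold lower number from compound 2 to compound 3 (0.05 log units; within the scatter), so the two groups cannot be told apart on this read-out, even though the triple bond is lost and fluorine takes the place of nitrogen. Set against hydrogen, trifluoromethyl gives a 14-fold lower number from compound 1 to compound 3 (1.13 log units; beyond the scatter), which shows that the large step at this site is not confined to cyano: two different groups, each ortho to a large group on the six-membered aromatic ring, both stand well apart from the hydrogen of compound 1. Nothing available explains why these two groups read alike here.

The compounds shown leave open how far this tolerance extends, since they do not tell whether a methyl, a chlorine, a methoxy or an amine on the same carbon would stay with compound 2 and compound 3 or fall back towards compound 1. They also leave open whether cyano or trifluoromethyl would produce a comparable step from any other carbon of that ring.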